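The source may report more compounds than this note shows. Statements on the series, on what has been measured and on what is new or still open speak of the compounds shown alone.

Measured compounds in the series:

Compound 1, `Cc1ccc(Cn2cc(CSC(=S)N3CCN(C(=O)NC(C)C)CC3)nn2)cc1`, in a functional assay on EC9706 cells (Homo sapiens) for cytotoxicity, read by MTT assay, with a stated time of 72 h (a higher number here means a weaker inhibitor, a lower number a stronger inhibitor), compound 1 gives only a limit of the assay, > 128000 nM.

Compound 2, `CCN(C)C(=O)N1CCN(C(=S)SCc2cn(Cc3ccc(C)cc3)nn2)CC1`, in this assay compound 2 gives 70600 nM.

Compound 3, `COc1cc(Cn2cc(CSC(=S)N3CCN(C(=O)NC(C)C)CC3)nn2)cc(OC)c1OC`, in this assay compound 3 gives only a limit of the assay, > 128000 nM.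

For the measured compounds named here, only one step is measured at both ends: an at least 1.8-fold lower number from compound 1 to compound 2 (0.25 log units; that floor lies within the scatter). The change behind it is ethyl(methyl)amino in place of isopropylamino on a carbonyl carbon. Because (the limit of > 128000 nM in this assay, at which 2 of the 3 values shown sit), this step is known only as a floor, and that floor lies within the usual scatter, so it cannot be read as a clear gain. The cores of compound 1 and compound 3 differ, but the difference between the two cores is not broken down here.

Compound 4, `CCN(C)C(=O)N1CCN(C(=S)SCc2cn(Cc3cc(OC)c(OC)c(OC)c3)nn2)CC1`, is not yet measured in this assay. It differs from compound 3 by ethyl(methyl)amino in place of isopropylamino on a carbonyl carbon. The place is described in the same words as for the step from compound 1 to compound 2, so this is the same change on the core of compound 3.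

For compound 4 the expected step is an at least 1.2-fold lower number from compound 3 to compound 4 (0.10 log units; that floor lies within the scatter), resting on an at least 1.8-fold lower number from compound 1 to compound 2 (0.25 log units; that floor lies within the scatter) and on compound 3 giving only a limit, > 128000 nM. Because (the limit of > 128000 nM in this assay, at which 2 of the 3 values shown sit), the chance that compound 4 also returns a limit rather than a number is considerable. Compound 4 is estimated at 100000 nM in this assay, with an expected range from 50000 nM to 200000 nM.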

Compound 4, half-maximal inhibitory concentration: > 128000 nM
Compound 4 gave a limit, no number (the forecaster's own chance of this, stated with the estimate: 45%); middle value at least 1.2-fold (0.10 log units) from the limit.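

Compound 3 and compound 4 both give only a limit in this assay, so no step between them can be read: the limit of > 128000 nM in this assay, at which 3 of the 4 values shown sit.

The compounds shown leave open whether ethyl(methyl)amino in place of isopropylamino on a carbonyl carbon shifts the read-out at all on the core of compound 3, and on the core of compound 1 beyond the floor already printed.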